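Methylating a Hydroxyl: Two Cores, One Kind of Change

The source may report more compounds than this note shows. Statements on the series, on what has been measured and on what is new or still open speak of the compounds shown alone.

Measured compounds:
compound 1 `COC(=O)CN(C)Cc1c(OC)cc(OC)c(C(=O)/C=C/c2ccccc2Cl)c1O`: 13900 nM
compound 2 `COc1cc(OC)c(C(=O)/C=C/c2ccccc2Cl)c(O)c1CN(C)CC(=O)O`: 44400 nM
compound 3 `COc1cc(O)c2c(=O)cc(-c3ccccc3Cl)oc2c1CN1CCCCC1`: 21500 nM

All three were examined in a functional assay on ECa-109 cells (Homo sapiens) for antiproliferative activity, with a stated time of 72 h; on this read-out higher numbers stand for weaker inhibition and lower numbers for stronger inhibition. Compound 2 and compound 1 differ in one place, (methyl in place of hydrogen on an oxygen next to a carbonyl group), and that step gave a 3.2-fold lower number from compound 2 to compound 1 (0.50 log units; beyond the scatter). Compound 3 carries a different core; how its core differs from that of compound 2 is not broken down here, and its values can only be set beside the others: in this assay compound 3 gives 21500 nM, which stands within the scatter of compound 1 and beyond it relative to compound 2.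

Compound 4 `COc1cc(OC)c2c(=O)cc(-c3ccccc3Cl)oc2c1CN1CCCCC1` is not yet measured. It differs from compound 3 by methyl in place of hydrogen on an oxygen on an aromatic ring. This is the same kind of change as that from compound 2 to compound 1, not the same one: there the methyl entered on an oxygen next to a carbonyl group, here it enters on an oxygen on an aromatic ring. Resting only on a 3.2-fold lower number from compound 2 to compound 1 (0.50 log units; beyond the scatter), and with the core of compound 3 untested for this change, a smaller step is expected for compound 4, a 1.4-fold lower number from compound 3 to compound 4 (0.16 log units; within the scatter). Compound 4 is therefore estimated at 15000 nM, between 5000 nM and 50000 nM.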

Compound 4, half-maximal inhibitory concentration: 23700 nM
The estimate for compound 4 lay 1.6-fold (0.20 log units) below the measured number; low and high end bracket the measured number.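

In this assay, methyl in place of hydrogen on an oxygen did not act alike on the two cores: the same change on two cores in this assay, a 3.2-fold lower number (0.50 log units; beyond the scatter) from compound 2 to compound 1 and a 1.1-fold higher number (0.04 log units; within the scatter) from compound 3 to compound 4, 3.5-fold (0.55 log units) apart, beyond the scatter of two such steps. On the core of compound 3, the change from hydroxy to methoxy gave a 1.1-fold higher number from compound 3 to compound 4 (0.04 log units; within the scatter) and so did not repeat the lower number seen on the other core. This does not show that the core alone sets the outcome, since the two pairs also differ in the oxygen that takes the methyl, which lies next to a carbonyl group in one pair and on an aromatic ring in the other, and each case rests on a single pair.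

The compounds shown leave open whether methylating the same oxygen on both cores would give matching steps. They also leave open how an ethyl group or a longer chain in place of the methyl would read in this assay on either core.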